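Swapping the Pyrazole for a Chloropyridinyl Ether

A few compounds are considered here, and "the series" means these few. Any claim that something is new, unique, unknown or untested is made for them only; others in the source may bear on it.

Three compounds have so far been measured in an assay on isolated protein for inhibition of G protein-coupled receptor kinase 5 (Homo sapiens), read by TR-FRET, with stated times of 10 min and 1 h; a higher number here means a weaker inhibitor, a lower number a stronger inhibitor:
compound 1 `CN(C)c1ccc2oc(-c3cc(-c4cnn(C5CCNCC5)c4)cnc3N)nc2c1` gives 1760 nM
compound 2 `CN(C)COc1cccc(-c2cnc(N)c(-c3nc4cccc(-c5ccccn5)c4o3)c2)c1` gives 5100 nM
compound 3 `Nc1ncc(-c2cnn(C3CCNCC3)c2)cc1-c1nc2ccc(-c3cn[nH]c3)cc2o1` gives 1780 nM

Compound 3 holds the second highest of these three numbers. Its value and that of compound 1 lie within the scatter of each other, whereas the gap to compound 2 lies beyond the scatter, compound 2 giving the higher number. Compound 4 `Nc1ncc(-c2cnn(C3CCNCC3)c2)cc1-c1nc2ccc(Oc3cc(Cl)ccn3)cc2o1` differs from compound 3 in a single place: (4-chloropyridin-2-yl)oxy in place of 1H-pyrazol-4-yl on an aromatic carbon. For the measured compounds named here, no measured pair shows this exchange, so nothing in the data points firmly in either direction. The expectation is therefore a step from compound 3 to compound 4 of a 1.2-fold lower number from compound 3 to compound 4 (0.07 log units; within the scatter), not beyond the scatter. Compound 4 is accordingly estimated at 1500 nM, with a range from 500 nM to 5000 nM.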

Compound 4, half-maximal inhibitory concentration: 5700 nM
The estimate for compound 4 lay 3.8-fold (0.58 log units) below the measured number; measured number outside the range, above it.
By their numbers in this assay, from the lowest: compounds 1 and 3 (each within the scatter of the next); then compounds 2 and 4 (each within the scatter of the next).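

On an aromatic carbon of the shared core, this assay shows a 3.2-fold higher number from compound 3 to compound 4 (0.51 log units; beyond the scatter) when (4-chloropyridin-2-yl)oxy takes the place of 1H-pyrazol-4-yl. For the compounds shown here, this is the only exchange at this position whose size can be read, and it shows that the position is sensitive to this change, though the step is modest. No available evidence accounts for the step.

From the compounds shown here alone, whether the higher number goes with the chlorine, the ether oxygen or the pyridine ring stays open. Going by these compounds, how a phenoxy group, a morpholine or a carboxylic acid would read on this carbon also stays open.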